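The source may report more compounds than this note shows. Statements on the series, on what has been measured and on what is new or still open speak of the compounds shown alone.

Measured so far: compound 1 `O=C1C=C(N2CCNCC2)C(=O)N1c1ccc(Cl)cc1`, compound 2 `O=C1C=C(N2CCCC2)C(=O)N1c1ccc(Cl)cc1` and compound 3 `O=C1C=C(N2CCNCC2)C(=O)N1c1ccc(F)cc1`. In a functional assay on the whole organism (strain NMRI BR) with Mus musculus as the target (on this read-out lower numbers stand for an effect already at smaller amounts and higher numbers for an effect only at larger amounts of compound), compound 1 gives 360 mg/kg. Compound 3 gives 289 mg/kg. For compound 2 the read-out is only a limit, > 300 mg/kg, not a number.

Among the two numbers compound 3 holds the lowest, with compound 1 close by through a 1.2-fold lower number from compound 1 to compound 3 (0.10 log units; within the scatter). Compound 4 `O=C1C=C(N2CCCC2)C(=O)N1c1ccc(F)cc1` differs from compound 3 by pyrrolidin-1-yl in place of piperazin-1-yl on a double-bonded ring carbon. Among the compounds with values here, the one measured step of this kind is a step that the limit leaves unreadable from compound 1 to compound 2, whose size is hidden because of the limit of > 300 mg/kg in this assay, at which 1 of the 3 values shown sits. The same outcome is expected here: compound 4 will probably again reach only a limit in this assay, so the step of a 1.7-fold higher number from compound 3 to compound 4 (0.24 log units; within the scatter) is an estimate of a rise rather than a reading. Compound 4 is therefore expected near 500 mg/kg, within 250 mg/kg to 1200 mg/kg.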

Compound 4, dose for half-maximal effect: > 200 mg/kg
Compound 4: no number, only a limit; the forecaster's own chance of this, stated with the estimate: 70%; the middle value lies beyond the limit too.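

Compound 2 and compound 4 each give only a limit in this assay, not a number, so the steps from compound 3 to compound 4 and from compound 2 to compound 4 cannot be read. The compounds shown leave open whether pyrrolidin-1-yl in place of piperazin-1-yl changes the dose needed for an effect.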